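Amide exchange on a carbonyl carbon of the shared core

The compounds below may be only part of what the source reports. "The series", "measured", "known", "first", "only" and "open" are said of these compounds alone.

- Compound 1 `N#CC1(NC(=O)[C@@H]2C[C@@H](S(=O)(=O)c3ccccc3)C[C@H]2C(=O)N2CC3(COC3)C2)CC1`: 248 nM
- Compound 2 `N#CC1(NC(=O)[C@@H]2C[C@@H](S(=O)(=O)c3ccccc3)C[C@H]2C(=O)Nc2ccc(F)cc2)CC1`: 391 nM

Going by the values given here, in a functional assay on A20 cells (Mus musculus) for inhibition, with stated times of 1 h, 16 h and 24 h (on this read-out lower numbers stand for stronger inhibition and higher numbers for weaker inhibition), compound 2 gives 391 nM and stands within the scatter of compound 1, the only other measured compound. The unmeasured compound 3 `CN(C)C(=O)[C@@H]1C[C@H](S(=O)(=O)c2ccccc2)C[C@H]1C(=O)NC1(C#N)CC1` differs from compound 2 by dimethylamino in place of (4-fluorophenyl)amino on a carbonyl carbon. Among the compounds with values here, only one measured step bears on this exchange: a 1.6-fold higher number from compound 1 to compound 2 (0.20 log units; within the scatter). That step also replaced the group on a carbonyl carbon, so no change beyond the scatter is expected in this assay. The expected step is a 1.2-fold lower number from compound 2 to compound 3 (0.09 log units; within the scatter). For compound 3 the estimate is 320 nM, with an expected range of 130 nM to 800 nM.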

Compound 3, half-maximal inhibitory concentration: 91 nM
The estimate for compound 3 lay 3.5-fold (0.55 log units) above the measured number; the whole stated range lies above it.
By their numbers in this assay, from the lowest: compound 3; then compounds 1 and 2 (each within the scatter of the next).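

At this carbonyl carbon the group does change the read-out in this assay, which the pair of compound 1 and compound 2 alone did not show: dimethylamino gives a 4.3-fold lower number from compound 2 to compound 3 (0.63 log units; beyond the scatter) and a 2.7-fold lower number from compound 1 to compound 3 (0.44 log units; beyond the scatter). Compound 3, the only one of the three without a ring in this group, has the lowest number, while the two ring-bearing groups of compound 1 and compound 2 stay within the scatter of each other. No measurement shown explains this step. Open, from the compounds shown here alone, is whether methylamino or diethylamino would match dimethylamino. A pyrrolidine would show whether a ring on this nitrogen is compatible with the lower number.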